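The source may report more compounds than this note shows. Statements on the series, on what has been measured and on what is new or still open speak of the compounds shown alone.

Of the compounds shown here, three of a shared core have been tested in an ADME assay on MT4 cells (Homo sapiens) for cytotoxicity, read by MTT assay; on this read-out higher numbers stand for lower toxicity in this test and lower numbers for higher toxicity in this test. Compound 1 `Cc1cc(/C=C/C#N)cc(C)c1Oc1ccnc(Nc2ccc(CN3CCN(S(=O)(=O)N(C)C)CC3)cc2)n1` gives 3070 nM in this assay. Compound 2 `Cc1cc(C#N)cc(C)c1Oc1ccnc(Nc2ccc(CN3CCN(S(=O)(=O)C4CC4)CC3)cc2)n1`, which carries a nitrile in place of the unsaturated nitrile and a cyclopropylsulfonyl piperazine, gives 4430 nM. Compound 3 `Cc1cc(/C=C/C#N)cc(C)c1Oc1ccnc(Nc2ccc(CN3CCCN(S(C)(=O)=O)CC3)cc2)n1` gives 17400 nM, the highest number of the three, set apart from compound 2 and from compound 1 by gaps that both lie beyond the scatter. Among the measured compounds shown here, the one step traced between measured compounds, a 5.7-fold higher number from compound 1 to compound 3 (0.75 log units; beyond the scatter), was modest but clear.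

The next compound, compound 4 `Cc1cc(/C=C/C#N)cc(C)c1Oc1ccnc(Nc2ccc(CN3CCN(S(=O)(=O)C4CC4)CC3)cc2)n1`, differs from compound 3 by 4-(cyclopropylsulfonyl)piperazin-1-yl in place of 4-(methylsulfonyl)-1,4-diazepan-1-yl on a saturated chain carbon bound to an aromatic carbon. This change reverses the ring part of the step from compound 1 to compound 3, returning to a piperazine, while the sulfonyl substituent becomes a cyclopropyl, as in compound 2. Since compound 1 and compound 2, both piperazines, sit close together and well below compound 3, the number for compound 4 is expected to fall back toward theirs, a step estimated as a 3.9-fold lower number from compound 3 to compound 4 (0.59 log units; beyond the scatter). Compound 4 is therefore estimated at 4500 nM, with a range from 2000 nM to 12000 nM.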

Compound 4, half-maximal cytotoxic concentration: 4350 nM
Compound 4: middle estimate off by 1.0-fold (0.01 log units), on the high side; measured number inside the range.
By their numbers in this assay, from the lowest: compounds 1, 4 and 2 (each within the scatter of the next); then compound 3.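

In this assay, 2-cyanoethenyl in place of cyano on an aromatic carbon makes no difference beyond the scatter when the chain carries 4-(cyclopropylsulfonyl)piperazin-1-yl, as the step of a 1.0-fold lower number from compound 2 to compound 4 (0.01 log units; within the scatter) shows. Cyclopropyl in place of dimethylamino on a sulfonyl sulfur likewise stays within the scatter, with a 1.4-fold higher number from compound 1 to compound 4 (0.15 log units; within the scatter) as its step, so the three piperazine compounds cannot be told apart in this test. Only the change on the saturated chain carbon bound to an aromatic carbon moves the number beyond the scatter, as a 4.0-fold lower number from compound 3 to compound 4 (0.60 log units; beyond the scatter) shows, and compound 3, the only one of the four with a seven-membered ring, stands alone at the high end. Nothing shown here bears on the reason for these numbers.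

The step from the diazepane to the piperazine also swaps methyl for cyclopropyl on the sulfonyl sulfur, so the compounds shown leave open which of the two parts carries the difference; a piperazine with methylsulfonyl or a diazepane with cyclopropylsulfonyl would separate them. Also open, from the compounds shown here alone, is what a morpholine ring, or an acetyl group in place of the sulfonyl, would give in this test.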